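Hydroxy to chloro on the anilide of compound 1

A few compounds are considered here, and "the series" means these few. Any claim that something is new, unique, unknown or untested is made for them only; others in the source may bear on it.

Compounds measured so far:
compound 1 `CN(C)C(=O)c1cc2cnc(Nc3ccc(NC(=O)C4(C(=O)Nc5ccc(O)cc5)CC4)cc3)nc2n1C1CCCC1` — 93.6%
compound 2 `COc1cccc(NC(=O)C2(C(=O)Nc3ccc(Nc4ncc5cc(C(=O)N(C)C)n(C6CCCC6)c5n4)cc3)CC2)c1` — 77.2%

Two compounds sharing one core have been run in a functional assay on A549 cells (Homo sapiens) for inhibition, read by CCK-8 assay, with a stated time of 72 h, tested at 1 uM; a lower number here means less inhibition of growth, a higher number more inhibition of growth at the concentration tested. Compound 1 `CN(C)C(=O)c1cc2cnc(Nc3ccc(NC(=O)C4(C(=O)Nc5ccc(O)cc5)CC4)cc3)nc2n1C1CCCC1` gives 93.6%, the higher of the two numbers. Compound 2 `COc1cccc(NC(=O)C2(C(=O)Nc3ccc(Nc4ncc5cc(C(=O)N(C)C)n(C6CCCC6)c5n4)cc3)CC2)c1` gives 77.2%. Going by the values given here, the only step so far is a number 16.4 percentage points lower from compound 1 to compound 2 (beyond the scatter), a 3-methoxyphenyl in place of 4-hydroxyphenyl on an amide-type nitrogen, which lowered growth inhibition beyond the scatter, so compound 1 stands at the top of what is known.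

Compound 3 `CN(C)C(=O)c1cc2cnc(Nc3ccc(NC(=O)C4(C(=O)Nc5ccc(Cl)cc5)CC4)cc3)nc2n1C1CCCC1` has not yet been measured. It differs from compound 1 as follows: chloro in place of hydroxy on an aromatic carbon. Among the compounds with values here, this keeps the phenyl ring and touches only the group on its aromatic carbon, so the one measured step, which swapped both the group and its position, bears on it only loosely. Compound 1 already sits near full inhibition in this assay, leaving little room upward. The step is therefore expected to be a number 5.6 percentage points lower from compound 1 to compound 3 (within the scatter), within the scatter. Compound 3 is estimated at 88%, with a range from 70% to 98%.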

Compound 3, percent growth inhibition at one concentration: 24.7%
Beside the measured number, compound 3's estimate is 63.3 percentage points above it; measured number below the stated range.
By their numbers in this assay, from the lowest: compound 3; then compound 2; then compound 1.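

In this assay, the change at this place is far from neutral: exchanging one heavy atom, with the phenyl ring and the rest of the molecule unchanged, gives a number 68.9 percentage points lower from compound 1 to compound 3 (beyond the scatter). The earlier step could not show this, since it changed the group and its place together and cost much less, whereas here the place stays on the aromatic carbon para to a large group and only hydroxy gives way to chloro. The second new step, a number 52.5 percentage points lower from compound 2 to compound 3 (beyond the scatter), shows that a 3-methoxyphenyl retains far more growth inhibition than a 4-chlorophenyl on the same amide nitrogen, although that comparison still mixes group and place, and nothing available explains the size of either drop.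

The compounds shown leave open whether the fall follows the hydrogen-bond donor and acceptor that leave with hydroxy or something specific to chloro, a question that an amino group or a fluoro at the same place would bear on. They also leave open how a methoxy at this same place would compare, which would separate the effect of the group from that of its place.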